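A Carbamoyl Group Takes the Place of Methyl

The compounds below may be only part of what the source reports. "The series", "measured", "known", "first", "only" and "open" are said of these compounds alone.

Compound 1 `N=c1c(C(N)=O)cc(Cl)cn1Cc1ccccc1`: 30 nM
Compound 2 `CS(=O)(=O)c1cccc(Cn2cc(Cl)cc(C(N)=O)c2=N)c1`: 52 nM
Compound 3 `Cc1cccc(Cn2cc(Cl)cc(C(N)=O)c2=N)c1`: 7.5 nM

Of the compounds shown here, three sharing one core have been measured in an assay on CHO-K1 cells for displacement of a labelled ligand from Alpha-1D adrenergic receptor (Homo sapiens), read by scintillation counting, with a stated time of 60 min; on this read-out lower numbers stand for stronger inhibition and higher numbers for weaker inhibition. Compound 3 gives the lowest number of the three: the step from compound 1 to compound 3 is a 4.0-fold lower number from compound 1 to compound 3 (0.60 log units; beyond the scatter), and the step from compound 2 to compound 3 is a 6.9-fold lower number from compound 2 to compound 3 (0.84 log units; beyond the scatter), both beyond the scatter. Compound 1 and compound 2 differ by a 1.7-fold higher number from compound 1 to compound 2 (0.24 log units; within the scatter), which lies within the scatter.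

Compound 4 `N=c1c(C(N)=O)cc(Cl)cn1Cc1cccc(C(N)=O)c1` has not yet been measured. It differs from compound 3 by carbamoyl in place of methyl on an aromatic carbon. Within the data shown here, the steps that bear on this change are the two that alter the same aromatic carbon: the gain from hydrogen to methyl in a 4.0-fold lower number from compound 1 to compound 3 (0.60 log units; beyond the scatter), and the exchange of methylsulfonyl for methyl in a 6.9-fold lower number from compound 2 to compound 3 (0.84 log units; beyond the scatter). A group other than methyl at this carbon has so far given a higher number in this assay, and a carbamoyl group is expected to behave more like the methylsulfonyl or the unsubstituted case than like methyl. The expected step is therefore a 4.7-fold higher number from compound 3 to compound 4 (0.67 log units; beyond the scatter), toward a higher number. Compound 4 is estimated at 35 nM, with a range from 12 nM to 100 nM.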

Compound 4, inhibition constant: 26 nM
Compound 4: middle estimate off by 1.3-fold (0.13 log units), on the high side; low and high end bracket the measured number.
By their numbers in this assay, from the lowest: compound 3; then compounds 4, 1 and 2 (each within the scatter of the next).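

In this assay, carbamoyl in place of methyl on this aromatic carbon gives a 3.5-fold higher number from compound 3 to compound 4 (0.54 log units; beyond the scatter), so a second group now stands apart from methyl, and this one brings a hydrogen-bond donor and a hydrogen-bond acceptor that methyl lacks. The carbamoyl group cannot be told apart from hydrogen, at a 1.2-fold lower number from compound 1 to compound 4 (0.06 log units; within the scatter), or from methylsulfonyl, at a 2.0-fold lower number from compound 2 to compound 4 (0.30 log units; within the scatter), since both steps lie within the scatter; among the four compounds shown, hydrogen, methylsulfonyl and carbamoyl therefore read alike at this carbon, and only the methyl of compound 3 gives a number beyond the scatter of all the others. Nothing available explains the place of methyl in this series.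

The compounds shown leave open whether the lower number belongs to methyl alone or extends to other small groups such as ethyl, chloro or methoxy at the same carbon. They also leave open how an amine or a carboxylic acid there would read in this assay.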